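Swapping the octyl chain for a methoxyphenyl ring

This account rests on a few compounds, and the source may have more. Where it says the series, first, only, none or still open, it means among the compounds named here.

Measured compounds:
compound 1 `CCCCCCCCNc1nc(SCc2ccc(C(F)(F)F)cc2)nc2ccccc12` gives 22300 nM
compound 2 `FC(F)(F)c1ccc(CSc2nc(Nc3ccccc3)c3ccccc3n2)cc1` gives 18400 nM
compound 3 `FC(F)(F)c1ccc(CSc2nc(Nc3ccc(Cl)cc3)c3ccccc3n2)cc1` gives 15100 nM

All three numbers come from a functional assay on MDA-MB-231 cells (Homo sapiens) for cytotoxicity, read by MTT assay, with a stated time of 72 h; on this read-out higher numbers stand for weaker inhibition and lower numbers for stronger inhibition. Compound 1 holds the largest of the three numbers, but it is not set apart: the step to compound 2 is a 1.2-fold lower number from compound 1 to compound 2 (0.08 log units; within the scatter), and the step to compound 3 is a 1.5-fold lower number from compound 1 to compound 3 (0.17 log units; within the scatter). Between those two aryl compounds the step is a 1.2-fold lower number from compound 2 to compound 3 (0.09 log units; within the scatter).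

Compound 4 `COc1ccc(Nc2nc(SCc3ccc(C(F)(F)F)cc3)nc3ccccc23)cc1` is not yet measured. It differs from compound 1 as follows: 4-methoxyphenyl in place of octyl on a nitrogen on an aromatic ring. Among the measured compounds shown here, the steps that bear on this change are the two already made from compound 1 to an aryl group on that same nitrogen, and both stayed within the scatter. Nothing here suggests that a 4-methoxyphenyl group would behave differently from phenyl or 4-chlorophenyl, so no step beyond the scatter is expected in this assay. Compound 4 is therefore estimated at 17000 nM, with a range from 8000 nM to 36000 nM. The expected step is a 1.3-fold lower number from compound 1 to compound 4 (0.12 log units; within the scatter).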

Compound 4, half-maximal inhibitory concentration: 15700 nM
Beside the measured number, compound 4's estimate is 1.1-fold (0.03 log units) above it; measured number inside the range.
By their numbers in this assay, from the lowest: compounds 3, 4, 2 and 1 (each within the scatter of the next).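

In this assay, a third aryl group on this nitrogen gives the same picture as the first two: a 1.4-fold lower number from compound 1 to compound 4 (0.15 log units; within the scatter) shows that 4-methoxyphenyl, with a hydrogen-bond acceptor that octyl lacks, does not separate itself from the chain. On the aromatic carbon of the ring, a 1.2-fold lower number from compound 2 to compound 4 (0.07 log units; within the scatter) for methoxy against hydrogen and a 1.0-fold higher number from compound 3 to compound 4 (0.02 log units; within the scatter) for methoxy against chloro mean that these three substituents cannot be told apart in this series. Nothing available explains why the numbers stay so close.

From the compounds shown here alone, it remains open whether any group on this nitrogen can move the number beyond the scatter, as all four compounds lie within it of one another. A carboxylic acid on the phenyl ring, a terminal amine on the octyl chain or a much shorter chain would test this.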